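Fluoro in Place of Hydrogen on the Core of Compound 1

The source may report more compounds than this note shows. Statements on the series, on what has been measured and on what is new or still open speak of the compounds shown alone.

Compound 1 `CCCCNc1nc(NCc2ccco2)c2ccccc2n1` is the starting point. In a functional assay on MCF7 cells (Homo sapiens) for cytotoxicity, read by MTT assay, with a stated time of 2 days, tested at 10 uM (a higher number here means more inhibition at the concentration tested (going by the name of the read-out), a lower number less inhibition), compound 1 gives 66.7%. Two companions carry the same core with a different chain on the amine. Compound 2 `Cc1cccc(N2CCN(CCCNc3nc(NCc4ccco4)c4ccccc4n3)CC2)c1C` gives 95.9% in this assay, a number that lies clearly beyond the usual scatter above compound 1. Compound 3 `CN(C)CCNc1nc(NCc2ccco2)c2ccccc2n1` gives "not determined" (no result reported) in this assay, so no result is reported for it. Among the two numbers at hand, compound 1 therefore stands lowest.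

Compound 4 `CCCCNc1nc(NCc2ccco2)c2cccc(F)c2n1` has not been measured. It differs from compound 1 in one place: fluoro in place of hydrogen on an aromatic carbon. Within the data shown here, no pair of measured compounds differs in a single place, so no measured step shows what such a small change does here. The expectation for compound 4 rests only on the value of compound 1, which is 66.7%, and on the smallness of the change, a single fluorine atom entering and nothing else.

The step from compound 1 to compound 4 is expected to be a number 1.3 percentage points higher from compound 1 to compound 4 (within the scatter), that is, no change beyond the scatter in either direction. Compound 4 is estimated to give 68% in this assay, with a range from 50% to 86%.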

Compound 4, a percentage reported as inhibition, at one concentration (the size of the read-out at that concentration, not a potency): 87%
The estimate for compound 4 lay 19 percentage points below the measured number; measured number above the stated range.
By their numbers in this assay, from the lowest: compound 1; then compounds 4 and 2 (each within the scatter of the next).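

Among these compounds, this is the first step that can be read from a single change, since compounds 1 and 2 differ in more than one place. In this assay, fluoro in place of hydrogen gives a number 20.3 percentage points higher from compound 1 to compound 4 (beyond the scatter) and so shows that this aromatic carbon of the core, ortho to a fused ring and meta to a fused ring, is not indifferent to substitution. The entering group adds only one heavy atom, with no ring, no hydrogen-bond donors, no hydrogen-bond acceptors and no net charge, yet that is enough to move the read-out at the one concentration tested, although nothing here measures potency or explains the rise.

As far as these compounds go, whether chloro, methoxy or an amine on the same carbon would move the number in the same way remains open, as does the effect of fluoro on the other carbons of that ring. Also open, from the compounds shown here alone, is whether the same fluoro change would alter the number of compound 2, which carries a far longer chain on the amine and already reads high at 95.9% in this test.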